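A few compounds are considered here, and "the series" means these few. Any claim that something is new, unique, unknown or untested is made for them only; others in the source may bear on it.

Measured compounds:
compound 1, `C=CCN(Cc1cccs1)C(=O)COc1ccc(C)cc1`, 20 nM
compound 2, `CCN(Cc1cccs1)C(=O)c1cc2cc(C)ccc2s1`, 1600 nM
compound 3, `Cc1ccc2oc(C(=O)N(Cc3cccs3)c3ccn[nH]3)cc2c1`, 40 nM

In an assay on HEK293 cells for agonist activity at transient receptor potential cation channel subfamily M member 8 (Homo sapiens), read by fluorescence and calcium flux, with a stated time of 15 min (a lower number here means that less compound is needed, a higher number that more compound is needed for the effect), compound 1 gives 20 nM, the lowest of the three numbers. Compound 3, with 40 nM, is the nearest to it and the two values lie within the usual scatter of this assay, so no order between compound 1 and compound 3 can be read from them. Compound 2, with 1600 nM, is the furthest away and its value lies well beyond the scatter, so compound 2 clearly needs more compound than compound 1 for the effect.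

The next compound, compound 4, `Cc1ccc(OCC(=O)N(O)Cc2cccs2)cc1`, differs from compound 1 in one place: hydroxy in place of allyl on an amide-type nitrogen. Within the data shown here, no pair of measured compounds shows a step of this kind, so there is no measured step to lean on. The change replaces a group without donors or acceptors by one carrying a donor and an acceptor, at the amide-type nitrogen of the shared core. The expectation is a moderate step towards a higher number, beyond the scatter, expressed as a 7.5-fold higher number from compound 1 to compound 4 (0.88 log units; beyond the scatter), because compound 1 sits at 20 nM and little room remains below it.

For compound 4 the expected value in this assay is 150 nM, within a range of 30 nM to 800 nM.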

Compound 4, half-maximal effective concentration: 8000 nM
For compound 4 the middle estimate is 53-fold (1.73 log units) below the measured one; the whole stated range lies below it.
By their numbers in this assay, from the lowest: compounds 1 and 3 (each within the scatter of the next); then compound 2; then compound 4.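

In this assay, hydroxy in place of allyl on the amide-type nitrogen gives a 400-fold higher number from compound 1 to compound 4 (2.60 log units; beyond the scatter), a large step and the first in this series that can be read at a single place. The earlier compounds shown here offered no pair differing in one place, so the effect of this nitrogen substituent could not be read from them; this pair shows that, with the rest of compound 1 held fixed, the group at this position strongly affects the number. The exchange removes 3 carbon heavy atoms with their double bond and brings in 1 oxygen with a hydrogen-bond donor and acceptor, and nothing measured here accounts for the size of the step.

Still open, as far as these compounds go, is whether the step follows from the loss of allyl or from the entry of hydroxy, which a propyl or methyl group or a methoxy group on the same nitrogen would help to separate. Among these compounds, also open is whether a step of this size would recur on the other cores, as no matching pair is available for them.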